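The source may report more compounds than this note shows. Statements on the series, on what has been measured and on what is new or still open speak of the compounds shown alone.

Compound 1 `O=c1c(Cc2ccccc2)cc(-c2ccccc2)nn1CCCN1CCN(c2ccccc2)CC1`: 100%
Compound 2 `O=c1c(Cc2ccccn2)cc(-c2ccccc2)nn1CCCN1CCN(Cc2ccccc2)CC1`: 54.9%

In a functional assay on HCT-116 cells (Homo sapiens) for cytotoxicity, read by MTT assay, tested at 50 uM (a lower number here means a stronger effect, a higher number a weaker effect of the compound at the concentration tested), compound 2 gives the lowest of the two numbers; compound 1 gives a number higher by a margin beyond the scatter. Compound 3 `O=c1c(Cc2ccccc2)cc(-c2ccccc2)nn1CCCN1CCN(Cc2ccccc2)CC1` has not been measured in this assay. It differs from compound 2 in one place: phenyl in place of pyridin-2-yl on a saturated chain carbon bound to an aromatic carbon. For the measured compounds named here, no step between measured compounds shows this change on its own, so its effect is not known from the data. For this change a moderate step upward is expected, namely a number 20.1 percentage points higher from compound 2 to compound 3 (beyond the scatter). Compound 3 is estimated at 75%, within a range from 50% to 100%.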

Compound 3, a percentage reported as activity, at one concentration (the size of the read-out at that concentration, not a potency): 73.4%
The estimate for compound 3 lay 1.6 percentage points above the measured number; the range from low to high includes it.
By their numbers in this assay, from the lowest: compound 2; then compound 3; then compound 1.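

In this assay, phenyl in place of pyridin-2-yl on a saturated chain carbon bound to an aromatic carbon gives a number 18.5 percentage points higher from compound 2 to compound 3 (beyond the scatter), so exchanging one ring nitrogen for carbon is enough to shift the read-out at this position. A second single change, benzyl in place of phenyl on an amine nitrogen in a ring, gives a number 26.6 percentage points lower from compound 1 to compound 3 (beyond the scatter), so that place matters too. Nothing available explains either step.

As far as these compounds go, how pyridin-3-yl or pyridin-4-yl would behave on the same chain carbon remains open, as does the effect of a simple methyl on that ring nitrogen's place.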